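Efficacy of 5-HT1D Agonists with Varied Amine Substituents

The compounds below may be only part of what the source reports. "The series", "measured", "known", "first", "only" and "open" are said of these compounds alone.

Compounds measured so far:
compound 1 `c1ccc(C2CCCCN2C2CCN(CCCc3c[nH]c4ccc(-n5cnnc5)cc34)CC2)cc1` – 65%
compound 2 `OC[C@H](NC1CCN(CCCc2c[nH]c3ccc(-n4ccnc4)cc23)CC1)c1ccccc1` – 74%
compound 3 `OC[C@H](NC1CCN(CCCc2c[nH]c3ccc(Cn4cncn4)cc23)CC1)c1ccccc1` – 76%

In a functional assay on CHO cells for activation of 5-hydroxytryptamine receptor 1D (Homo sapiens), read by GTPgammaS binding (on this read-out higher numbers stand for larger maximal responses and lower numbers for smaller maximal responses), compound 3 gives the largest of the three values; the value of compound 2 lies within the scatter of it, and only compound 1 lies beyond. Among the measured compounds shown here, the one step measured so far, a number 2 percentage points higher from compound 2 to compound 3 (within the scatter), concerns the substituent on the aromatic ring and leaves the amine side untouched.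

Compound 4 `COC[C@H](NC1CCN(CCCc2c[nH]c3ccc(Cn4cncn4)cc23)CC1)c1ccc(F)cc1` is the next compound. Its change from compound 3 is 1-(4-fluorophenyl)-2-methoxyethyl in place of 2-hydroxy-1-phenylethyl on an amine nitrogen. For the measured compounds named here, no measured step touches this amine nitrogen, so no step bears directly on the change; the three values known in this assay all fall within a narrow band, with compound 1, built differently at that position, giving the lowest number. Compound 4 is therefore expected to give 72%, between 58% and 85%, which amounts to an expected a number 4 percentage points lower from compound 3 to compound 4 (within the scatter), a change not beyond the scatter.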

Compound 4, largest response reached (reported as efficacy), in percent of the reference or control that the assay uses: 89%
Beside the measured number, compound 4's estimate is 17 percentage points below it, outside the stated range (above it).
By their numbers in this assay, from the lowest: compounds 1, 2 and 3 (each within the scatter of the next, the first and the last beyond it); then compound 4.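

In this assay the amine nitrogen proves to be a place where the response can move: a number 13 percentage points higher from compound 3 to compound 4 (beyond the scatter) when 1-(4-fluorophenyl)-2-methoxyethyl replaces 2-hydroxy-1-phenylethyl. The earlier step, a number 2 percentage points higher from compound 2 to compound 3 (within the scatter), changed only the substituent on the aromatic ring, so this is the only step shown that lies beyond the scatter, and it places compound 4 above all three earlier compounds. The change drops the hydrogen-bond donor of the leaving group and adds a fluorine, but nothing measured here explains the rise.

The single step changes the ring and the oxygen end of the group together, so the compounds shown do not separate the contribution of the fluorine from that of the methoxy. They also leave open how a chlorine on the phenyl ring, or an amine or a carboxylic acid in place of the methoxy, would read.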